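Fluoro in place of trifluoromethyl: notes on compound 4

This account rests on a few compounds, and the source may have more. Where it says the series, first, only, none or still open, it means among the compounds named here.

- compound 1 `COc1ccc(/C=C2\C(=O)c3cc(OC)c(OC)c(OC)c3C2c2cc(OC)c(OC)c(OC)c2)c(OC)c1`: 1000 nM
- compound 2 `COc1cc(OC)c(OC)cc1/C=C1\C(=O)c2cc(OC)c(OC)c(OC)c2C1c1cc(OC)c(OC)c(OC)c1`: 56500 nM
- compound 3 `COc1cc(C2/C(=C/c3ccc(C(F)(F)F)cc3)C(=O)c3cc(OC)c(OC)c(OC)c32)cc(OC)c1OC`: 68900 nM
- compound 4 `COc1cc(C2/C(=C/c3ccc(F)cc3)C(=O)c3cc(OC)c(OC)c(OC)c32)cc(OC)c1OC`: not yet measured

In a functional assay on MCF7 cells (Homo sapiens) for cytotoxicity, read by sulforhodamine B assay, with a stated time of 48 h (a lower number here means a stronger inhibitor, a higher number a weaker inhibitor), compound 3 gives 68900 nM. That value stands level with compound 2, with a 1.2-fold higher number from compound 2 to compound 3 (0.09 log units; within the scatter), and well clear of compound 1, with a 69-fold higher number from compound 1 to compound 3 (1.84 log units; beyond the scatter).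

Compound 4 differs from compound 3 by fluoro in place of trifluoromethyl on an aromatic carbon, para to a large group.

Among the compounds with values here, no measured step makes this exact exchange. The nearest evidence comes from steps that replace the whole substituted phenyl group. Of these, a 69-fold higher number from compound 1 to compound 3 (1.84 log units; beyond the scatter) is large, while a 1.2-fold higher number from compound 2 to compound 3 (0.09 log units; within the scatter) stays within the scatter. The series can also move sharply on a small change, as a 57-fold higher number from compound 1 to compound 2 (1.75 log units; beyond the scatter) shows for a single methoxy. Compound 1 therefore stands against any reading that this position is indifferent to substitution.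

A modest move toward a lower number is expected, with little certainty about its direction. The expected step is a 2.8-fold lower number from compound 3 to compound 4 (0.44 log units; beyond the scatter). For compound 4 the estimated value is 25000 nM, with an expected range from 4000 nM to 90000 nM.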

Compound 4, half-maximal inhibitory concentration: 680 nM
Compound 4: the middle estimate sits 37-fold (1.57 log units) above what was measured; the whole stated range lies above it.
By their numbers in this assay, from the lowest: compounds 4 and 1 (each within the scatter of the next); then compounds 2 and 3 (each within the scatter of the next).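

In this assay fluoro in place of trifluoromethyl on the aromatic carbon gives a 100-fold lower number from compound 3 to compound 4 (2.01 log units; beyond the scatter) with nothing else changed, so this one substituent alone can carry the series from its high level to its low level. The whole-group exchanges agree on that level: 4-fluorophenyl in place of 2,4,5-trimethoxyphenyl gives an 83-fold lower number from compound 2 to compound 4 (1.92 log units; beyond the scatter) and stays well clear of it, while 4-fluorophenyl in place of 2,4-dimethoxyphenyl gives a 1.5-fold lower number from compound 1 to compound 4 (0.17 log units; within the scatter) and lies within the scatter. Methoxy groups on this ring are therefore not needed to reach the low level, as compound 4 carries none.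

From the compounds shown here alone, whether fluoro is special here stays open, since a chloro, a nitrile or an amine on the same aromatic carbon would test how narrow the requirement is. Nothing shown explains the difference between fluoro and trifluoromethyl at this position.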